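Replacing the 4-iodophenyl of compound 1 with an open chain

The source may report more compounds than this note shows. Statements on the series, on what has been measured and on what is new or still open speak of the compounds shown alone.

Compound 1 `FC(F)(F)c1cccc(NC(=S)Nc2ccc(I)cc2)c1` and compound 2 `N#Cc1ccc(NC(=S)Nc2cccc(C(F)(F)F)c2)cc1` share a core and differ in one place. In an ADME assay on BHK cells (Mesocricetus auratus) for cytotoxicity, read by MTT assay, with a stated time of 96 h (a higher number here means that more compound is tolerated, a lower number that less compound is tolerated), compound 1 gives 9400 nM, the lowest of the two numbers, and compound 2 gives 9500 nM; the step of a 1.0-fold higher number from compound 1 to compound 2 (0.00 log units; within the scatter) stays within the scatter. Compound 3 `CSCCCNC(=S)Nc1cccc(C(F)(F)F)c1` is not yet measured. Its change from compound 1 is 3-(methylsulfanyl)propyl in place of 4-iodophenyl on an amide-type nitrogen. Going by the values given here, no measured step exchanges a ring for a chain on the amide-type nitrogen; the single step on record, from compound 1 to compound 2, concerns only a substituent on an aromatic carbon and gave no movement beyond the scatter, so it bears on the present change only loosely. Compound 3 is therefore expected to land near compound 1, with a step of a 1.1-fold higher number from compound 1 to compound 3 (0.03 log units; within the scatter) that is not expected to exceed the scatter. The estimate for compound 3 is 10000 nM, within a range from 3000 nM to 32000 nM.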

Compound 3, half-maximal cytotoxic concentration: > 100000 nM
Compound 3 gave a limit, no number; the forecaster's own chance of this, stated with the estimate: 10%; middle value at least 10-fold (1.00 log units) from the limit.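

Notes on the amide-type nitrogen: in this assay, 3-(methylsulfanyl)propyl in place of 4-iodophenyl gives an at least 10-fold higher number from compound 1 to compound 3 (1.02 log units; beyond the scatter), whereas the exchange on the aromatic carbon gave a 1.0-fold higher number from compound 1 to compound 2 (0.00 log units; within the scatter). Among the compounds shown, the group on this nitrogen is therefore the only place where a change moves the number beyond the scatter, and the aromatic ring at this position is not needed for the series to be read in this assay. The entry for compound 3 is a limit and not a number: the limit of > 100000 nM in this assay, at which 1 of the 3 values shown sits.

The compounds shown do not tell whether the step follows from losing the ring, from the sulfur or from the chain itself. A plain butyl chain, a cyclohexyl ring or a chain ending in an amine on the same nitrogen would bear on that question.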